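Shifting the Chlorine Around the Pendant Phenyl Ring

The source may report more compounds than this note shows. Statements on the series, on what has been measured and on what is new or still open speak of the compounds shown alone.

Compound 3 `COc1ccccc1N1CCN(CCn2c(=O)[nH]c3cc(-c4ccccc4Cl)[nH]c3c2=O)CC1` stands second highest of the three numbers in an assay for binding affinity to Adrenergic receptor alpha-1 (Rattus norvegicus) (a higher number here means a weaker inhibitor, a lower number a stronger inhibitor), where compound 3 gives 0.76 nM. Its nearest neighbour is compound 2 `COc1ccccc1N1CCN(CCn2c(=O)[nH]c3cc(-c4ccccc4)[nH]c3c2=O)CC1` with 0.52 nM, and the furthest is compound 1 `COc1ccccc1N1CCN(CCn2c(=O)[nH]c3cc[nH]c3c2=O)CC1` with 2.31 nM. Compound 4 `COc1ccccc1N1CCN(CCn2c(=O)[nH]c3cc(-c4cccc(Cl)c4)[nH]c3c2=O)CC1` differs from compound 3 by 3-chlorophenyl in place of 2-chlorophenyl on an aromatic carbon. Two measured steps, a 4.4-fold lower number from compound 1 to compound 2 (0.65 log units; beyond the scatter) and a 3.0-fold lower number from compound 1 to compound 3 (0.48 log units; beyond the scatter), show that an aryl group at this carbon lowers the number modestly, while a 1.5-fold higher number from compound 2 to compound 3 (0.16 log units; within the scatter) shows the chloro adding nothing beyond the scatter. With the chlorine merely moved to another position on that phenyl, compound 4 is expected to show no step beyond the scatter, a 1.1-fold lower number from compound 3 to compound 4 (0.04 log units; within the scatter). Compound 4 is therefore estimated at 0.7 nM, within 0.3 nM to 1.8 nM.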

Compound 4, inhibition constant: 19.3 nM
The estimate for compound 4 lay 28-fold (1.44 log units) below the measured number; measured number outside the range, above it.
By their numbers in this assay, from the lowest: compounds 2 and 3 (each within the scatter of the next); then compound 1; then compound 4.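

At this carbon, next to the ring nitrogen, the position of the chlorine on the phenyl matters in this assay, with a 25-fold higher number from compound 3 to compound 4 (1.40 log units; beyond the scatter) on moving it and a 37-fold higher number from compound 2 to compound 4 (1.57 log units; beyond the scatter) on adding it as 3-chlorophenyl, whereas the 2-chlorophenyl step stayed within the scatter. Compound 4 also goes against the earlier lowering by an aryl group here, with an 8.4-fold higher number from compound 1 to compound 4 (0.92 log units; beyond the scatter) in place of a drop. Nothing available explains this difference between the two chlorophenyl groups. The compounds shown leave open how 4-chlorophenyl or a methoxyphenyl would read at this carbon, and whether a group other than chlorine at the 3-position of the phenyl would raise the number as well.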